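From hydroxy to acetoxy on compound 2

This account rests on a few compounds, and the source may have more. Where it says the series, first, only, none or still open, it means among the compounds named here.

Compound 1 `CCN(CC)C(=O)Cn1c(=O)c(-c2ccc(OC)cc2)cc2c(OC)cc(OC)cc21` in a functional assay on HCT-15 cells (Homo sapiens) for cytotoxicity, read by colorimetric assay and MTT assay (a higher number here means a weaker inhibitor, a lower number a stronger inhibitor), gives 10000 nM
Compound 2 `COc1cc(OC)c2cc(-c3ccc(O)cc3)c(=O)n(C)c2c1` in this assay gives 10000 nM

Compound 2 stands level with compound 1 at the digits shown, within the scatter. Compound 3 `COc1cc(OC)c2cc(-c3ccc(OC(C)=O)cc3)c(=O)n(C)c2c1` differs from compound 2 in one place: acetyl in place of hydrogen on an oxygen on an aromatic ring, or hydroxy to acetoxy. Within the data shown here, no measured pair shows this change in this assay, and from compound 2 at 10000 nM no step beyond the scatter is expected in either direction. The expected change, no change at the digits printed from compound 2 to compound 3 (within the scatter), stays within the scatter. For compound 3 the estimated value is 10000 nM, with an expected range from 4000 nM to 20000 nM in this reading.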

Compound 3, half-maximal inhibitory concentration: 10000 nM
The estimate for compound 3 equals the measured number at the digits printed, and the stated range covers the measured number.
By their numbers in this assay, from the lowest: compounds 1, 2 and 3 (each within the scatter of the next).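

In this assay the change from hydroxy to acetoxy gives no change at the digits printed from compound 2 to compound 3 (within the scatter) and is the only one-place comparison shown, so this oxygen on an aromatic ring now has a direct reading: acetyl in place of hydrogen there does not separate the two compounds. No available evidence bears on this result.

The compounds shown leave open whether a different group at this position, such as an amine or a carboxylic acid, would give a value outside the scatter of compound 2 at 10000 nM in this reading.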